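Title: From an ester to a methyl on a trifluoromethyl ketone

This account rests on a few compounds, and the source may have more. Where it says the series, first, only, none or still open, it means among the compounds named here.

Among the compounds with values here, compound 2 `COC(=O)c1ccc2ccc(C(=O)c3ccc(C(F)(F)F)cc3)c-2cc1` stands lowest of the two numbers so far in an assay on cells for displacement of a labelled ligand from Orexin/Hypocretin receptor type 1 (Homo sapiens), read by scintillation counting, with stated times of 10 min and 90 min, tested at 10 uM; a lower number here means less inhibition, a higher number more inhibition at the concentration tested (going by the name of the read-out): compound 2 gives -60.5%, while compound 1 `COC(=O)c1ccc2ccc(C(=O)c3ccccc3)c-2cc1` gives 7.2%, a step of a number 67.7 percentage points lower from compound 1 to compound 2 (beyond the scatter). Compound 3 `Cc1ccc2ccc(C(=O)c3ccc(C(F)(F)F)cc3)c-2cc1` differs from compound 2 by methyl in place of methoxycarbonyl on an aromatic carbon. Within the data shown here, no measured step touches this change; the single known step concerns a different group, so nothing here bears directly on the new exchange. The expected step from compound 2 is therefore a number 5.5 percentage points higher from compound 2 to compound 3 (within the scatter), within the scatter. Compound 3 is estimated to give -55%, somewhere between -100% and 0%.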

Compound 3, a percentage reported as inhibition, at one concentration (the size of the read-out at that concentration, not a potency): 38.3%
Beside the measured number, compound 3's estimate is 93.3 percentage points below it; the whole stated range lies below it.
By their numbers in this assay, from the lowest: compound 2; then compound 1; then compound 3.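

Methyl in place of methoxycarbonyl on this aromatic carbon gives a number 98.8 percentage points higher from compound 2 to compound 3 (beyond the scatter) in this assay, a large change from one exchange. This shows that the number depends strongly on the group at this position, not only on the trifluoromethyl change seen earlier. No measurement shown here explains why the number moves this way. As far as these compounds go, whether the same exchange would have a similar effect on compound 1, which lacks trifluoromethyl, remains open. So does the result of placing a carboxylic acid, an amine or a longer chain at this position.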